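Swapping a fluorophenyl for a trifluoromethylphenyl on a weak blocker

The compounds below may be only part of what the source reports. "The series", "measured", "known", "first", "only" and "open" are said of these compounds alone.

Two measured compounds frame this step. Compound 1 `CN(Cc1ccc(OCCCN)cc1)c1nc2ccc(Oc3cccc(C(F)(F)F)c3)cc2s1` is tested in an assay on SH-SY5Y cells for inhibition of Voltage-dependent N-type calcium channel subunit alpha-1B (Homo sapiens), read by FLIPR and calcium flux, with stated times of 600 s and 300 s, in the presence of a further agent that is not named here (a higher number here means a weaker inhibitor, a lower number a stronger inhibitor), and gives 77000 nM. Compound 2 `NCCCOc1ccc(CNc2nc3ccc(Oc4ccc(F)cc4)cc3s2)cc1` gives, in this assay, 106000 nM. Compound 2 has the higher of the two numbers, but its nearest neighbour is compound 1, and the gap between them lies within the scatter, so the two cannot be told apart on these data. Both are weak inhibitors.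

Compound 3 `NCCCOc1ccc(CNc2nc3ccc(Oc4cccc(C(F)(F)F)c4)cc3s2)cc1` has not yet been measured. It differs from compound 2 in one place: 3-(trifluoromethyl)phenyl in place of 4-fluorophenyl on an oxygen on an aromatic ring. Compound 3 also shares its aryl ether with compound 1, differing from compound 1 only in the group on the nitrogen, so the two measured compounds bracket the new one from both sides without any step beyond the scatter between them. Compound 3 is therefore expected to show no step beyond the scatter, as a 1.2-fold lower number from compound 2 to compound 3 (0.10 log units; within the scatter) conveys. Compound 3 is estimated at 85000 nM, with a range from 35000 nM to 200000 nM.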

Compound 3, half-maximal inhibitory concentration: 144000 nM
Estimate against measurement, compound 3: 1.7-fold (0.23 log units) below, within the range that was stated.
By their numbers in this assay, from the lowest: compounds 1, 2 and 3 (each within the scatter of the next).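

In this assay, 3-(trifluoromethyl)phenyl in place of 4-fluorophenyl on the oxygen gives a 1.4-fold higher number from compound 2 to compound 3 (0.13 log units; within the scatter), so with the nitrogen carrying hydrogen, these two aryl groups cannot be told apart, even though the entering group has 10 heavy atoms against 7 for the one it replaces. Among the compounds shown here, the compounds now also offer a direct reading of the nitrogen: with 3-(trifluoromethyl)phenoxy held constant, hydrogen in place of methyl gives a 1.9-fold higher number from compound 1 to compound 3 (0.27 log units; within the scatter), so removing that methyl produces no step that can be distinguished from repeat-measurement noise, and neither change yet marks a place where the number responds. No independent measurement bears on these results, so they offer no basis for assigning a cause.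

On these data alone, each change rests on a single pair of compounds, so it remains open whether either would read the same on a different version of the shared core. As far as these compounds go, it also remains open whether a pyridine ring or a cyclohexyl group on that oxygen, or an ethyl group on that nitrogen, would produce a step beyond the scatter.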